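The compounds below may be only part of what the source reports. "The series", "measured", "known", "first", "only" and "open" are said of these compounds alone.

Compound 1 `Fc1cccc(-c2nc(Nc3ccccc3)c3cc(F)ccc3n2)c1` is a weak inhibitor in a functional assay on COLO 205 cells (Homo sapiens) for cytotoxicity, read by MTT assay, with a stated time of 48 h (a lower number here means a stronger inhibitor, a higher number a weaker inhibitor), where compound 1 gives 49700 nM. Compound 2 `COc1ccc(Nc2nc(-c3cccc(F)c3)nc3ccc(F)cc23)cc1` carries a methoxy in place of hydrogen on an aromatic carbon, and in this assay compound 2 gives 46800 nM; the two numbers sit together, separated only by a 1.1-fold lower number from compound 1 to compound 2 (0.03 log units; within the scatter). Compound 3 `Fc1cccc(-c2nc(Nc3cccc(Br)c3)c3cc(F)ccc3n2)c1` carries bromo in place of hydrogen on an aromatic carbon, and in this assay compound 3 reaches only a limit, > 50000 nM, so the step of a number no lower from compound 1 to compound 3 (the limit leaves the size open) has a size that cannot be read (the limit of > 50000 nM in this assay, at which 1 of the 3 values shown sits).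

Compound 4 `Oc1ccccc1Nc1nc(-c2cccc(F)c2)nc2ccc(F)cc12` differs from compound 1 in one place: hydroxy in place of hydrogen on an aromatic carbon. The two measured steps that bear on it both change a hydrogen on the same aromatic ring for a small group, and neither moved the number beyond the scatter. A step beyond the scatter is therefore not expected in this assay for compound 4, in either direction.

The estimate for compound 4 in this assay is 50000 nM, with a range from 25000 nM to 100000 nM, and a fair chance that only a limit is reported. This estimate means an expected step of a 1.0-fold higher number from compound 1 to compound 4 (0.00 log units; within the scatter).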

Compound 4, half-maximal inhibitory concentration: > 50000 nM
Compound 4: no number, only a limit; the forecaster's own chance of this, stated with the estimate: 45%; the middle value lies on the limit itself.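

The hydroxy of compound 4 is the first group shown ortho to a large group on this phenyl ring, and it is also the first to bring a hydrogen-bond donor there. In this assay, compound 4 gives only a limit, > 50000 nM, not a number. That leaves a number no lower from compound 1 to compound 4 (the limit leaves the size open), and an at least 1.0-fold higher number from compound 2 to compound 4 (0.02 log units; that floor lies within the scatter), while the step between compound 3 and compound 4 cannot be read. Hydroxy at this place therefore gives no sign of a stronger compound than the anilino compounds before it, and the result ends at the same limit as compound 3: the limit of > 50000 nM in this assay, at which 2 of the 4 values shown sit.

As far as these compounds go, whether an amine or a carboxylic acid at this same place, or a longer chain such as ethoxy, would bring the number clearly down stays open. Also open, from the compounds shown here alone, is how weak compound 3 and compound 4 really are, and whether the hydroxy has any effect at all on the value of compound 1, which lies close to that limit.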